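Cytotoxicity on Vero cells: three esters at the limit

A few compounds are considered here, and "the series" means these few. Any claim that something is new, unique, unknown or untested is made for them only; others in the source may bear on it.

Three close relatives share one core and differ only in the aromatic ester at its far end. Compound 1 `O=C(OC1CCC(CN2CCN(c3cc(=O)c4cc(C(F)(F)F)cc([N+](=O)[O-])c4s3)CC2)CC1)c1cccc(F)c1` carries a 3-fluorophenyl ester, compound 2 `COc1cccc(C(=O)OC2CCC(CN3CCN(c4cc(=O)c5cc(C(F)(F)F)cc([N+](=O)[O-])c5s4)CC3)CC2)c1` a 3-methoxyphenyl ester, and compound 3 `O=C(OC1CCC(CN2CCN(c3cc(=O)c4cc(C(F)(F)F)cc([N+](=O)[O-])c4s3)CC2)CC1)c1ccc(F)cc1` a 4-fluorophenyl ester. All three were tested in an ADME assay on Vero cells (Chlorocebus sabaeus) for cytotoxicity, read by MTT assay, with a stated time of 48 h; on this read-out lower numbers stand for stronger inhibition and higher numbers for weaker inhibition. In this assay compound 1 reaches only the limit of the test, > 64 ug/mL. Compound 2 likewise sits at the limit, > 64 ug/mL. Compound 3 also gives no number but a limit, > 64 ug/mL.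

Every value is a limit. The steps between these compounds therefore cannot be sized: a step that the two limits leave unreadable from compound 1 to compound 2, and the same holds for a step that the two limits leave unreadable from compound 1 to compound 3 and a step that the two limits leave unreadable from compound 2 to compound 3. The evidence is simply (the limit of > 64 ug/mL in this assay, at which 3 of the 3 values shown sit).

The change from compound 1 to compound 2 is methoxy in place of fluoro on an aromatic carbon. The cores of compound 1 and compound 3 differ by 4-fluorophenyl in place of 3-fluorophenyl on a carbonyl carbon. Compound 4 `COc1ccc(C(=O)OC2CCC(CN3CCN(c4cc(=O)c5cc(C(F)(F)F)cc([N+](=O)[O-])c5s4)CC3)CC2)cc1`, not yet measured, relates to compound 3 by methoxy in place of fluoro on an aromatic carbon. This is the same kind of change as from compound 1 to compound 2, though the place differs: there the new group sits meta to a large group, here para to a large group.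

Compound 1 gives only a limit, > 64 ug/mL. Compound 2 also gives only a limit, > 64 ug/mL. On that footing the step from compound 3 to compound 4 in this assay is expected to be a number no higher from compound 3 to compound 4 (the limit leaves the size open). Compound 4 is therefore estimated at 64 ug/mL, most likely again reported only as a limit.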

Compound 4, half-maximal inhibitory concentration: > 64 ug/mL
Compound 4: no number, only a limit; the forecaster's own chance of this, stated with the estimate: 85%; the middle value lies on the limit itself.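

In this assay compound 4 gives no number but a limit, > 64 ug/mL. The steps linking compound 4 to compound 1, compound 2 and compound 3 therefore cannot be read, and no size can be given for any of them: the limit of > 64 ug/mL in this assay, at which 4 of the 4 values shown sit.

The compounds shown leave open where the true value of each of the four lies, and whether their aromatic esters differ in cytotoxicity at all.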